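A Nitro for Bromo Swap Tried on a Second Core

The source may report more compounds than this note shows. Statements on the series, on what has been measured and on what is new or still open speak of the compounds shown alone.

Of the compounds shown here, three have so far been measured in a functional assay on PANC-1 cells (Homo sapiens) for antiproliferative activity, read by fluorescence and resazurin assay, with a stated time of 48 h; a higher number here means a weaker inhibitor, a lower number a stronger inhibitor. Compound 1 `O=C(N/N=C/c1cc2ccccc2nc1Cl)c1cc2cc(Br)ccc2oc1=O` gives 5450 nM. Compound 2 `Cc1noc(NS(=O)(=O)c2ccc(NC(=O)c3cc4cc([N+](=O)[O-])ccc4oc3=O)cc2)c1C` gives 11900 nM, and compound 3 `Cc1noc(NS(=O)(=O)c2ccc(NC(=O)c3cc4cc(Br)ccc4oc3=O)cc2)c1C` gives 28700 nM. Compound 1 thus holds the lowest of the three numbers, with compound 2 as its nearest neighbour and compound 3 as its furthest. Compounds 3 and 2 share a core and differ in one place, (nitro in place of bromo on an aromatic carbon), and this change gave a 2.4-fold lower number from compound 3 to compound 2 (0.38 log units; beyond the scatter). How the core of compound 1 differs from that of compound 3 is not broken down here.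

Compound 4 `O=C(N/N=C/c1cc2ccccc2nc1Cl)c1cc2cc([N+](=O)[O-])ccc2oc1=O` has not yet been measured. It differs from compound 1 in one place, (nitro in place of bromo on an aromatic carbon); the place is described in the same words as for the pair of compounds 3 and 2, so this is the same kind of change on a different core. A lower number is expected for compound 4 than for compound 1 because a 2.4-fold lower number from compound 3 to compound 2 (0.38 log units; beyond the scatter) was seen for this change before. The step from compound 1 to compound 4 in this assay is estimated as a 2.4-fold lower number from compound 1 to compound 4 (0.37 log units; beyond the scatter). Compound 4 is therefore expected near 2300 nM, between 1000 nM and 5500 nM.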

Compound 4, half-maximal inhibitory concentration: 38800 nM
Beside the measured number, compound 4's estimate is 17-fold (1.23 log units) below it, outside the stated range (above it).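

In this assay, the swap of nitro in place of bromo on an aromatic carbon did not carry over to the core of compound 1, where it gave a 7.1-fold higher number from compound 1 to compound 4 (0.85 log units; beyond the scatter), whereas on the core of compound 3 it had given a 2.4-fold lower number from compound 3 to compound 2 (0.38 log units; beyond the scatter). The two steps run in opposite directions, and the gap is larger than the scatter allows: the same change on two cores in this assay, a 2.4-fold lower number (0.38 log units; beyond the scatter) from compound 3 to compound 2 and a 7.1-fold higher number (0.85 log units; beyond the scatter) from compound 1 to compound 4, 17-fold (1.23 log units) apart, beyond the scatter of two such steps This shows that, in this series, the step seen on one core cannot be relied on to predict even the direction of the step on another, but it does not show why the two cores part, and two pairs cannot say which result a further core would follow.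

The compounds shown carry only bromo and nitro at this place, so it remains open how an amine or a methoxy group would read there on either core. Also open, going by these compounds, is whether a carboxylic acid at the same place would show the same split from one core to the other.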